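This account rests on a few compounds, and the source may have more. Where it says the series, first, only, none or still open, it means among the compounds named here.

Working notes on the series.

In a functional assay on HL-60 cells (Homo sapiens) for cytotoxicity, read by luminescence and CellTiter-Glo, with a stated time of 3 days (on this read-out lower numbers stand for stronger inhibition and higher numbers for weaker inhibition), compound 1 `O=C(Nc1ccc(C(F)(F)F)cc1)c1cc(Cl)c(-c2ccccc2)cc1O` gives 490 nM. Among the compounds with values here, compound 2 `N#Cc1ccc(NC(=O)c2ccc(-c3cccnc3)cc2O)cc1` in this assay gives 6660 nM, the highest of the two numbers in hand; the only neighbour is compound 1, whose number is lower by a gap that lies well beyond the scatter. Compound 3 `N#Cc1ccc(NC(=O)c2ccccc2O)cc1` is not yet measured.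

The change from compound 2 to compound 3 is hydrogen in place of pyridin-3-yl on an aromatic carbon. It sits on an aromatic carbon of the six-membered ring of carbon only, meta to a hydroxy group and para to a large group. Within the data shown here, no measured pair in hand isolates this change, so its size can only be guessed from the fact that compound 2, the smaller-substituted of the two measured compounds, already carries the higher number.

For compound 3 the expectation is a further rise, with the step of a 2.3-fold higher number from compound 2 to compound 3 (0.35 log units; beyond the scatter) estimated to exceed the scatter. Compound 3 is therefore estimated at 15000 nM in this assay, within a range from 4000 nM to 50000 nM.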

Compound 3, half-maximal inhibitory concentration: 4620 nM
For compound 3 the middle estimate is 3.2-fold (0.51 log units) above the measured one; the measured number falls inside the stated range.
By their numbers in this assay, from the lowest: compound 1; then compounds 3 and 2 (each within the scatter of the next).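

In this assay the step of a 1.4-fold lower number from compound 2 to compound 3 (0.16 log units; within the scatter) shows that, on this aromatic carbon, meta to a hydroxy group and para to a large group, hydrogen in place of pyridin-3-yl gives no difference that can be read. A substituent of six heavy atoms on this carbon therefore carries no readable weight in this assay, at least with the nitrile-bearing anilide held constant. Nothing in hand offers an explanation for this.

Going by these compounds, whether the same holds for other groups on this carbon, such as an amine or a carboxylic acid, stays open. Compound 1 differs from compound 2 and compound 3 in more than one place, so its lower number cannot yet be assigned to its chlorine, its phenyl or its trifluoromethyl group.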